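Swapping the Ether Side Chain: Compound 3 to Compound 4

A few compounds are considered here, and "the series" means these few. Any claim that something is new, unique, unknown or untested is made for them only; others in the source may bear on it.

Of the compounds shown here, three built on one shared core have been measured in an assay on isolated protein for displacement of a labelled ligand from Apoptosis regulator Bcl-2 (Homo sapiens), with a stated time of 15 min; a lower number here means a stronger inhibitor, a higher number a weaker inhibitor. Compound 1 `CC1(C)CCC(CN2CCN(c3ccc(C(=O)NS(=O)(=O)c4ccc(NCC5CCOC5)c([N+](=O)[O-])c4)c(Oc4cnc5[nH]ccc5c4)c3)CC2)=C(c2ccc(C(F)(F)F)cc2)C1` gives 4.7 nM, compound 2 `CC1(C)CCC(CN2CCN(c3ccc(C(=O)NS(=O)(=O)c4ccc(NC5CCOC5)c([N+](=O)[O-])c4)c(Oc4cnc5[nH]ccc5c4)c3)CC2)=C(c2ccc(C(F)(F)F)cc2)C1` gives 1.9 nM, and compound 3 `CC(Oc1ccc(S(=O)(=O)NC(=O)c2ccc(N3CCN(CC4=C(c5ccc(C(F)(F)F)cc5)CC(C)(C)CC4)CC3)cc2Oc2cnc3[nH]ccc3c2)cc1[N+](=O)[O-])C1CCOCC1` gives 9.2 nM, the highest of the three numbers. The step of a 2.0-fold higher number from compound 1 to compound 3 (0.29 log units; within the scatter) falls within the scatter, while a 4.8-fold higher number from compound 2 to compound 3 (0.69 log units; beyond the scatter) and a 2.5-fold lower number from compound 1 to compound 2 (0.39 log units; beyond the scatter) are modest. Compound 4 `CCN1CCC(COc2ccc(S(=O)(=O)NC(=O)c3ccc(N4CCN(CC5=C(c6ccc(C(F)(F)F)cc6)CC(C)(C)CC5)CC4)cc3Oc3cnc4[nH]ccc4c3)cc2[N+](=O)[O-])CC1` differs from compound 3 by (1-ethylpiperidin-4-yl)methyl in place of 1-(oxan-4-yl)ethyl on an oxygen on an aromatic ring. Within the data shown here, none of the measured steps changes this attachment in the same way, so they bear only loosely on it; together they show that variation at this point has moved the number modestly at most. The step of a 1.7-fold lower number from compound 3 to compound 4 (0.22 log units; within the scatter) is therefore expected to remain small. Compound 4 is estimated at 5.5 nM, with a range of 1.5 nM to 20 nM, in this assay.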

Compound 4, half-maximal inhibitory concentration: 0.5 nM
Beside the measured number, compound 4's estimate is 11-fold (1.04 log units) above it; measured number below the stated range.
By their numbers in this assay, from the lowest: compound 4; then compound 2; then compounds 1 and 3 (each within the scatter of the next).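

In this assay, among these compounds, the oxygen on the aromatic ring proves a sensitive place: (1-ethylpiperidin-4-yl)methyl in place of 1-(oxan-4-yl)ethyl brings an 18-fold lower number from compound 3 to compound 4 (1.26 log units; beyond the scatter) and a large step, where the earlier compounds showed only modest ones. Measured against the amino-linked side chains, (1-ethylpiperidin-4-yl)methoxy also brings a 3.8-fold lower number from compound 2 to compound 4 (0.58 log units; beyond the scatter) and a 9.4-fold lower number from compound 1 to compound 4 (0.97 log units; beyond the scatter) as well, each beyond the scatter. The compounds shown leave open how much of the gain belongs to the ring nitrogen, its ethyl group or the lost branch, which an (oxan-4-yl)methyl or (piperidin-4-yl)methyl group on the same oxygen would help separate. No evidence is available here to explain the result.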